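Aryl swap on the oxadiazole: compound 1 toward compound 4

The compounds below may be only part of what the source reports. "The series", "measured", "known", "first", "only" and "open" are said of these compounds alone.

Three compounds of the shared core have numbers in a functional assay on the whole organism for inhibition, with Mythimna separata as the target, with a stated time of 5 days; on this read-out higher numbers stand for an effect only at larger amounts of compound and lower numbers for an effect already at smaller amounts. Compound 1 `CC(C)(C)n1ncc(OCc2nnc(-c3ccccc3Cl)o2)c(Cl)c1=O` gives 61200 nM and stands as the lowest of the two numbers reported. Compound 3 `CCCCn1ncc(OCc2nnc(-c3ccc(F)cc3)o2)c(Cl)c1=O` gives 161000 nM, a gap beyond the usual scatter, although compound 3 also differs from compound 1 in its other substituents, so no single-change step can be read from the pair. Compound 2 `CCn1ncc(OCc2nnc(-c3ccccc3)o2)c(Cl)c1=O` is reported only as a limit of this assay, > 299000 nM, and not as a number; (the limit of > 299000 nM in this assay, at which 1 of the 3 values shown sits). Among the measured compounds shown here, no two measured compounds differ in one place, so no measured step exists.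

Compound 4 `CC(C)(C)n1ncc(OCc2nnc(-c3cc(F)c(F)cc3F)o2)c(Cl)c1=O` is not yet measured. It differs from compound 1 by 2,4,5-trifluorophenyl in place of 2-chlorophenyl on an aromatic carbon. For the measured compounds named here, with no measured step to draw on, the expected change from compound 1 to compound 4 is a 1.1-fold higher number from compound 1 to compound 4 (0.06 log units; within the scatter), no larger than the scatter in either direction. Compound 4 is therefore estimated at 70000 nM, within a range from 25000 nM to 200000 nM.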

Compound 4, half-maximal effective concentration: 75700 nM
For compound 4 the middle estimate is 1.1-fold (0.03 log units) below the measured one, and the stated range covers the measured number.
By their numbers in this assay, from the lowest: compounds 1 and 4 (each within the scatter of the next); then compound 3. At a limit, above all of these: compound 2.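

In this assay, among the compounds shown here, the exchange of 2-chlorophenyl for 2,4,5-trifluorophenyl gives the first single-place step, a 1.2-fold higher number from compound 1 to compound 4 (0.09 log units; within the scatter). On the background of compound 1, this aromatic carbon of the five-membered ring therefore accepts a phenyl group carrying fluorine in place of one carrying chlorine, with no change beyond the scatter. Nothing measured here gives a reason for this outcome.

On these data alone, whether the number at this position would move with a phenyl group carrying an amine or a carboxylic acid remains open. Also open, as far as these compounds go, is whether the same exchange would stay within the scatter on a background with a different group on the ring nitrogen, such as a longer chain.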